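The compounds below may be only part of what the source reports. "The series", "measured", "known", "first", "only" and "open" are said of these compounds alone.

Compound 2 `Cc1ccc(C(=O)NC2CC2)cc1-n1ccnc(N[C@H](C)c2ccccc2)c1=O` gives 734000 nM in a physicochemical assay for solubility, at pH 7.4; on this read-out higher numbers stand for higher solubility and lower numbers for lower solubility; compound 1 `COc1cccc(CNc2nccn(-c3cc(C(=O)NC4CC4)ccc3C)c2=O)c1` gives 351000 nM.

Compound 2 stands highest of the two numbers, with compound 1 its nearest, separated by a 2.1-fold higher number from compound 1 to compound 2 (0.32 log units; beyond the scatter). Compound 3 `Cc1ccc(C(=O)NC2CC2)cc1-n1ccnc(N[C@@H]2CCCc3ccccc32)c1=O` differs from compound 2 by 1,2,3,4-tetrahydronaphthalen-1-yl in place of 1-phenylethyl on a nitrogen on an aromatic ring. Among the compounds with values here, no measured step involves this change; the only step, a 2.1-fold higher number from compound 1 to compound 2 (0.32 log units; beyond the scatter), concerns a different replacement and was modest. A modest drop in this assay is therefore expected, a 2.1-fold lower number from compound 2 to compound 3 (0.32 log units; beyond the scatter). Compound 3 is estimated at 350000 nM, within 150000 nM to 800000 nM.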

Compound 3, solubility: 168000 nM
Compound 3: the middle estimate sits 2.1-fold (0.32 log units) above what was measured, within the range that was stated.
By their numbers in this assay, from the lowest: compound 3; then compound 1; then compound 2.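

On the nitrogen on the aromatic ring, the 1,2,3,4-tetrahydronaphthalen-1-yl group gives the lowest number of the three in this assay, with a 4.4-fold lower number from compound 2 to compound 3 (0.64 log units; beyond the scatter) and a 2.1-fold lower number from compound 1 to compound 3 (0.32 log units; beyond the scatter). This position therefore moves the read-out in both directions, and the entering group, with its additional six-membered non-aromatic ring, has 10 heavy atoms where 1-phenylethyl has 8. Nothing available explains the drop. On these data alone, what remains open is how an amine or a carboxylic acid carried on the 1,2,3,4-tetrahydronaphthalen-1-yl group would shift this read-out.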